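The compounds below may be only part of what the source reports. "The series", "measured", "known", "first", "only" and "open" are said of these compounds alone.

Measured compounds:
compound 1, `O=C(O)CCC(=O)OCCCCCCSc1ccc([N+](=O)[O-])c2nonc12`, 8740 nM in a functional assay on HOS cells (Homo sapiens) for inhibition, read by MTT assay, with a stated time of 72 h; a lower number here means a stronger inhibitor, a higher number a weaker inhibitor
compound 2, `O=C(CCC(=O)OCCCCCCSc1ccc([N+](=O)[O-])c2nonc12)Nc1cccc(Cl)c1`, 1920 nM

Compound 1 has the highest of the two numbers, with compound 2 the nearest at a 4.6-fold lower number from compound 1 to compound 2 (0.66 log units; beyond the scatter). Compound 3, `CN(C)CCCNC(=O)CCC(=O)OCCCCCCSc1ccc([N+](=O)[O-])c2nonc12`, differs from compound 1 in one place: (3-(dimethylamino)propyl)amino in place of hydroxy on a carbonyl carbon. Going by the values given here, the only measured step that bears on this is the one from compound 1 to compound 2, a different amide at the same carbonyl carbon; it gave a modest step beyond the scatter. A step of similar direction and probably smaller size is expected here, a 2.5-fold lower number from compound 1 to compound 3 (0.40 log units; beyond the scatter). Compound 3 is therefore estimated at 3500 nM, in the range 1200 nM to 10000 nM.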

Compound 3, half-maximal inhibitory concentration: 1850 nM
Beside the measured number, compound 3's estimate is 1.9-fold (0.28 log units) above it; the measured number falls inside the stated range.
By their numbers in this assay, from the lowest: compounds 3 and 2 (each within the scatter of the next); then compound 1.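

In this assay, (3-(dimethylamino)propyl)amino in place of hydroxy on the carbonyl carbon gives a step beyond the scatter (a 4.7-fold lower number from compound 1 to compound 3 (0.67 log units; beyond the scatter)), so an amide without a ring also departs from the acid. Exchanging 3-chlorophenyl for 3-(dimethylamino)propyl on the amide nitrogen leaves the reading within the scatter (a 1.0-fold lower number from compound 2 to compound 3 (0.02 log units; within the scatter)), so these two quite different amides cannot be told apart here. Nothing available explains this match. From the compounds shown here alone, whether a morpholine or a primary amine at the end of the chain would read the same remains open. So does whether a shorter chain on the amide nitrogen would.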